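The source may hold more compounds than are shown below. What is called first, only, known or untested is meant among the compounds shown, and "the series" means these compounds.

Measured so far:
- compound 1 `O=[N+]([O-])c1ccccc1S(=O)(=O)N1CC(n2cnc3ncnc(Sc4ccccc4)c32)OCc2ccccc21` gives 2590 nM in a functional assay on MCF7 cells (Homo sapiens) for antiproliferative activity; on this read-out higher numbers stand for weaker inhibition and lower numbers for stronger inhibition
- compound 2 `Nc1ccc(S(=O)(=O)N2CC(n3cc(F)c(=O)[nH]c3=O)OCc3ccccc32)cc1` gives 14400 nM in this assay

Of these two numbers, compound 1 has the lower one, and compound 2 sits at a number clearly beyond the scatter above it. Compound 3 `O=[N+]([O-])c1ccc(S(=O)(=O)N2CC(n3cnc4ncnc(Sc5ccccc5)c43)OCc3ccccc32)cc1` is not yet measured. It differs from compound 1 in one place: 4-nitrophenyl in place of 2-nitrophenyl on a sulfonyl sulfur. Going by the values given here, nothing measured so far shows what such a rearrangement does in this assay, so the step is expected to be small, in either direction, and the value of compound 3 is estimated at 2500 nM (range 800 nM to 8000 nM), meaning an expected step of a 1.0-fold lower number from compound 1 to compound 3 (0.02 log units; within the scatter).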

Compound 3, half-maximal inhibitory concentration: 860 nM
Beside the measured number, compound 3's estimate is 2.9-fold (0.46 log units) above it; low and high end bracket the measured number.
By their numbers in this assay, from the lowest: compound 3; then compound 1; then compound 2.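

In this assay, 4-nitrophenyl in place of 2-nitrophenyl on the sulfonyl sulfur gives a 3.0-fold lower number from compound 1 to compound 3 (0.48 log units; beyond the scatter) with the same atoms joined differently. This shows that activity at this position depends on where the nitro group sits on the phenyl ring, not only on which atoms are present. Nothing available explains why the number falls.

Still open, on these data alone, is whether the nitro group itself matters, which a plain phenyl, 4-methoxyphenyl or 4-carboxyphenyl on the same sulfur could test on the core of compound 3.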